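This account rests on a few compounds, and the source may have more. Where it says the series, first, only, none or still open, it means among the compounds named here.

In a functional assay on HCC827 cells (Homo sapiens) for antiproliferative activity, read by MTT assay, with a stated time of 72 h (on this read-out higher numbers stand for weaker inhibition and lower numbers for stronger inhibition), compound 1 `CN1CCN(c2ccc(Nc3ncc4nc([S+]([O-])c5ccccc5)n([C@H]5CC[C@H](O)CC5)c4n3)cc2)CC1` gives 268 nM. That value lies within the scatter of compound 3 `CN(C)CCN(C)c1ccc(Nc2ncc3nc(Sc4ccccc4)n(C4CCOCC4)c3n2)cc1` at 499 nM, whereas compound 2 `CN(C)CCN(C)c1ccc(Nc2ncc3nc([S+]([O-])c4ccccc4)n(C4CCOCC4)c3n2)cc1` reads 1330 nM, a clearly higher number than that of compound 1. Compound 4 `CN1CCN(c2ccc(Nc3ncc4nc([S+]([O-])c5ccccc5)n(C5CCCC5)c4n3)cc2)CC1` differs from compound 1 by cyclopentyl in place of 4-hydroxycyclohexyl on an aromatic nitrogen. Among the measured compounds shown here, the only measured step, a 2.7-fold lower number from compound 2 to compound 3 (0.43 log units; beyond the scatter), is modest and concerns a group on an aromatic carbon, leaving the group on that nitrogen unchanged. No measurement therefore tests this change directly, and no shift beyond the scatter is expected in this assay. The expected size is a 1.5-fold higher number from compound 1 to compound 4 (0.17 log units; within the scatter). Compound 4 is estimated at 400 nM, with an expected range of 120 nM to 1300 nM.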

Compound 4, half-maximal inhibitory concentration: 64.7 nM
The estimate for compound 4 lay 6.2-fold (0.79 log units) above the measured number; measured number outside the range, below it.
By their numbers in this assay, from the lowest: compound 4; then compounds 1 and 3 (each within the scatter of the next); then compound 2.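

In this assay, among the compounds shown here, the group on the aromatic nitrogen carries weight: cyclopentyl in place of 4-hydroxycyclohexyl gives a 4.1-fold lower number from compound 1 to compound 4 (0.62 log units; beyond the scatter) as the first step read at this position, whereas the only earlier step concerned a group on an aromatic carbon. The change alters ring size and removes the hydrogen-bond donor and acceptor together, and this single step does not separate them. No evidence is available on why the number shifts.

The compounds shown leave open how an unsubstituted cyclohexyl would compare with cyclopentyl. They also leave open whether an amine on the cyclohexyl ring would read like the hydroxyl.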